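Adding a Methyl Group on the Second Urotensin-2 Receptor Core

The source may hold more compounds than are shown below. What is called first, only, known or untested is meant among the compounds shown, and "the series" means these compounds.

Compound 1, `Cc1ccc(C)c(C(=O)OC(CCN(C)C)c2ccc(Cl)cc2)c1`: in an assay on NIH3T3 cells with Urotensin-2 receptor (Homo sapiens) as the target (on this read-out higher numbers stand for an effect only at larger amounts of compound and lower numbers for an effect already at smaller amounts), compound 1 gives 1860 nM.
Compound 2, `Cc1cc(C)c(C(=O)OC(CCN(C)C)c2ccc(Cl)cc2)cc1C`: in this assay compound 2 gives 468 nM.
Compound 3, `Cc1ccc(C)c(C(=O)NC(CCN(C)C)c2ccc(Cl)cc2)c1`: in this assay compound 3 gives 2880 nM.

Compound 1 and compound 2 share one core and differ in a single place: methyl in place of hydrogen on an aromatic carbon. This change made a 4.0-fold lower number from compound 1 to compound 2 (0.60 log units; beyond the scatter). Compound 3 is built on a second core; the difference between the two cores of compound 1 and compound 3 is not broken down here. Compound 3 has the highest of the three numbers, but compound 3 and compound 1 lie within the scatter of each other, whereas compound 2 lies beyond the scatter from compound 3.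

Compound 4, `Cc1cc(C)c(C(=O)NC(CCN(C)C)c2ccc(Cl)cc2)cc1C`, has not yet been measured. For the measured compounds named here, it differs from compound 3 by methyl in place of hydrogen on an aromatic carbon, which is the same change, in the same surroundings, as the one made from compound 1 to compound 2. Going by the values given here, on this basis the expected step is a 3.4-fold lower number from compound 3 to compound 4 (0.53 log units; beyond the scatter), kept a little short of the earlier one because on the first core the same change gave a 4.0-fold lower number from compound 1 to compound 2 (0.60 log units; beyond the scatter) and only that one example exists. Compound 4 is therefore estimated at 850 nM, in a range from 350 nM to 2000 nM.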

Compound 4, half-maximal effective concentration: 1780 nM
Compound 4: middle estimate off by 2.1-fold (0.32 log units), on the low side; measured number inside the range.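

On the core of compound 3, methyl in place of hydrogen on an aromatic carbon gives a 1.6-fold lower number from compound 3 to compound 4 (0.21 log units; within the scatter), so in this assay compound 4 cannot be told apart from compound 3, whereas on the core of compound 1 the same change gave a step beyond the scatter. Even so, the two steps themselves cannot be told apart, and the series gives no firm sign that the change acts differently on the two cores: the same change on two cores in this assay, a 4.0-fold lower number (0.60 log units; beyond the scatter) from compound 1 to compound 2 and a 1.6-fold lower number (0.21 log units; within the scatter) from compound 3 to compound 4, 2.5-fold (0.39 log units) apart, within the scatter of two such steps. For the compounds shown here, this shows that the result on the core of compound 1 is not clearly repeated on the core of compound 3, but it does not show that the change fails to carry over, nor that it carries over in full, and with only two pairs it supports no rule for other cores.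

The compounds shown leave open how an ethyl group, a methoxy group or a chlorine atom, set in place of the added methyl, would read in this assay on either core. They also leave open whether the same methyl change would give a similar step with a longer chain or a diethylamino group in place of the dimethylamino chain.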